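A Second Methyl on the Chain of a Long Amide

A few compounds are considered here, and "the series" means these few. Any claim that something is new, unique, unknown or untested is made for them only; others in the source may bear on it.

Compound 2, `CCCCCCCCCCCCCCC(C)C(=O)Nc1c(OC)cc(OC)cc1OC`, is an amide in which a long saturated chain is joined to an aromatic core carrying methoxy groups. In an assay on microsomes from intestine for inhibition of acyl-CoA:cholesterol acyltransferase (Oryctolagus cuniculus) (on this read-out higher numbers stand for weaker inhibition and lower numbers for stronger inhibition), compound 2 gives 31 nM. Its companion compound 1, `CCCCCCCCC(C)(C)C(=O)Nc1c(OC)cc(OC)cc1OC`, has a shorter chain and a second methyl on the saturated chain carbon bound to the carbonyl carbon; in this assay compound 1 gives 59 nM. Of the two numbers that of compound 2 is the lower one, but the gap to compound 1 lies within the scatter of repeated measurements, so the two compounds cannot be told apart with confidence.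

Compound 3, `CCCCCCCCCCCCCCC(C)(C)C(=O)Nc1c(OC)cc(OC)cc1OC`, has not yet been measured. It differs from compound 2 in one place: methyl in place of hydrogen on a saturated chain carbon bound to a carbonyl carbon and two saturated chain carbons. Compound 1 already carries such a second methyl and still sits near compound 2, because compound 1 gives 59 nM. In this assay a step beyond the scatter is therefore not expected in either direction. Compound 3 is expected to give 40 nM, with a likely range from 15 nM to 110 nM. This expectation corresponds to a step of a 1.3-fold higher number from compound 2 to compound 3 (0.11 log units; within the scatter), which is expected to stay within the usual scatter.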

Compound 3, half-maximal inhibitory concentration: 44 nM
Compound 3: middle estimate off by 1.1-fold (0.04 log units), on the low side; measured number inside the range.
By their numbers in this assay, from the lowest: compounds 2, 3 and 1 (each within the scatter of the next).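

In this assay, methyl in place of hydrogen on the saturated chain carbon bound to the carbonyl carbon gives a 1.4-fold higher number from compound 2 to compound 3 (0.15 log units; within the scatter) and so stays within the scatter; on this long chain, the position takes a second methyl with no readable change in the number. The pair that shares the second methyl now gives a separate comparison: hexyl in place of hydrogen on a saturated chain carbon, nine bonds along the chain from a carbonyl carbon, gives a 1.3-fold lower number from compound 1 to compound 3 (0.13 log units; within the scatter) and also stays within the scatter, so this added length has no readable effect on the number either. No measurement here offers an explanation for either result.

The three compounds leave open whether anything other than a methyl would be tolerated on this carbon, such as an ethyl, a hydroxyl or an amine, which could move the number beyond the scatter or leave it in place. They also leave open what a longer chain or a carboxylic acid at the far end of the chain would do, since both of these steps concern only a methyl and a hexyl.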